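Hydroxy for Methoxy: Growth Inhibition in Colon Cancer Cells

The source may report more compounds than this note shows. Statements on the series, on what has been measured and on what is new or still open speak of the compounds shown alone.

For the measured compounds named here, compound 1 `COc1cc(-c2nn(-c3cccc(NC(=O)Nc4cc(C(F)(F)F)cc(C(F)(F)F)c4)c3)cc2-c2ccncc2)ccc1Cl` is the only member of this set with a number in a functional assay on SW-620 cells (Homo sapiens) for inhibition, read by sulforhodamine B assay, with a stated time of 48 h; a lower number here means a stronger inhibitor of growth, a higher number a weaker inhibitor of growth: compound 1 gives 1860 nM. Compound 2 `COc1cc(-c2nn(-c3cccc(NC(=O)Nc4ccc(Cl)c(Cl)c4)c3)cc2-c2ccncc2)ccc1Cl` differs from compound 1 in more than one place, and the difference between the two cores is not broken down here. In this assay compound 2 reaches only a limit, > 50000 nM (the limit of > 50000 nM in this assay, at which 1 of the 3 values shown sits). Compound 3 `O=C(Nc1cccc(-n2cc(-c3ccncc3)c(-c3ccc(Cl)c(O)c3)n2)c1)Nc1ccc(Cl)c(Cl)c1` carries the change (hydrogen in place of methyl on an oxygen on an aromatic ring). In this assay compound 3 likewise stops at a limit, > 32500 nM (the limit of > 32500 nM in this assay, at which 1 of the 3 values shown sits). The step that the two limits leave unreadable from compound 2 to compound 3 therefore cannot be sized. Compound 4 `O=C(Nc1cccc(-n2cc(-c3ccncc3)c(-c3ccc(Cl)c(O)c3)n2)c1)Nc1cc(C(F)(F)F)cc(C(F)(F)F)c1` bears the same change relative to compound 1, (hydrogen in place of methyl on an oxygen on an aromatic ring). With no readable precedent, the step of a 1.6-fold higher number from compound 1 to compound 4 (0.21 log units; within the scatter) is expected to be modest. Compound 4 is accordingly estimated at 3000 nM, somewhere between 800 nM and 15000 nM.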

Compound 4, concentration for total growth inhibition: 5110 nM
The estimate for compound 4 lay 1.7-fold (0.23 log units) below the measured number, and the stated range covers the measured number.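

In this assay, a 2.7-fold higher number from compound 1 to compound 4 (0.44 log units; beyond the scatter) marks the one readable case of hydroxy for methoxy, and it shows a modest loss of growth inhibition on the core of compound 1. Compound 2 gives only a limit, not a number: the limit of > 50000 nM in this assay, at which 1 of the 4 values shown sits. Compound 3 also gives only a limit, so the same change on the core of compound 2 cannot be sized, and a single readable pair does not show whether the change carries from one core to another: the limit of > 32500 nM in this assay, at which 1 of the 4 values shown sits.

The compounds shown leave open how an amine or an ethoxy group in place of the methoxy would read in this assay. They also leave open whether the step on the core of compound 1 would hold on a third core.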